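The source may report more compounds than this note shows. Statements on the series, on what has been measured and on what is new or still open speak of the compounds shown alone.

Measured compounds:
Compound 1 `CCCn1cc2c(Nc3ccc(OC(F)(F)F)cc3)ncnc2n1`: in an ADME assay on BaF3 cells (Mus musculus) for cytotoxicity (a lower number here means that less compound is needed, a higher number that more compound is needed for the effect), compound 1 gives > 10000 nM, a limit of the assay and not a number.
Compound 2 `COc1ccc(Nc2cc(-c3ccncc3)ncn2)cc1`: in this assay compound 2 gives > 10000 nM, again only a limit.
Compound 3 `FC(F)(F)c1ccc(Nc2cc(-c3ccncc3)ncn2)cc1`: in this assay compound 3 gives > 10000 nM, again only a limit.

Compound 1 therefore stands nowhere in particular on a numerical scale. Going by the values given here, all three values sit at the limit of > 10000 nM in this assay, at which 3 of the 3 values shown sit, so no compound can be ranked against another. Among the compounds with values here, the only step between measured neighbours that differ in one place, a step that the two limits leave unreadable from compound 2 to compound 3, trifluoromethyl in place of methoxy on an aromatic carbon, is not readable in size. Both of its ends are limits.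

Compound 4 `FC(F)(F)Oc1ccc(Nc2ncnc3nn(Cc4cccnc4)cc23)cc1` differs from compound 1 by pyridin-3-yl in place of ethyl on a saturated chain carbon bound to an aromatic nitrogen. Within the data shown here, no measured step bears on this change, and the one step that exists gives no size to lean on. What can be said rests on (the limit of > 10000 nM in this assay, at which 3 of the 3 values shown sit), where every value sits. Compound 4 is expected to stay at the limit as well, with an estimate of 15000 nM and a range from 5000 nM to 60000 nM. The step that the limit leaves unreadable from compound 1 to compound 4 is expected to be none beyond the scatter, with the number itself most likely reported only as a limit.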

Compound 4, half-maximal effective concentration: > 10000 nM
Compound 4: only a limit was reported (the forecaster's own chance of this, stated with the estimate: 85%); the middle value is on the limit's open side.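

Compound 1 and compound 4 are both reported only as limits of the assay and not as numbers, and the size of the step between them cannot be read. The compounds shown leave open at what concentration any of them would reach the half-maximal effect in this assay.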